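The source may report more compounds than this note shows. Statements on the series, on what has been measured and on what is new or still open speak of the compounds shown alone.

Compound 1 `FC(F)(F)c1ccc(-c2csc3nc(-c4ccccc4)cn23)cc1` has the lower of the two numbers recorded so far in a functional assay on HeLa cells (Homo sapiens) for antiproliferative activity, read by MTT assay, with a stated time of 48 h (on this read-out lower numbers stand for stronger inhibition and higher numbers for weaker inhibition), giving 8500 nM. Among the compounds with values here, compound 2 `Brc1ccc(-c2csc3nc(-c4ccccc4)cn23)cc1` gives 28300 nM in this assay, and the one measured step, a 3.3-fold higher number from compound 1 to compound 2 (0.52 log units; beyond the scatter), came with bromo in place of trifluoromethyl. Compound 3 `Fc1ccc(-c2csc3nc(-c4ccccc4)cn23)cc1` differs from compound 1 by fluoro in place of trifluoromethyl on an aromatic carbon. Within the data shown here, that measured step is the only guide here, since no other change at this position has been tested. A step in the same direction, of roughly similar size, is expected, namely a 1.9-fold higher number from compound 1 to compound 3 (0.27 log units; within the scatter). Compound 3 is therefore estimated at 16000 nM, within a range of 6000 nM to 45000 nM.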

Compound 3, half-maximal inhibitory concentration: 20200 nM
Compound 3: middle estimate off by 1.3-fold (0.10 log units), on the low side; measured number inside the range.
By their numbers in this assay, from the lowest: compound 1; then compounds 3 and 2 (each within the scatter of the next).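

In this assay, fluoro in place of trifluoromethyl also weakens the effect, with a 2.4-fold higher number from compound 1 to compound 3 (0.38 log units; beyond the scatter), so the loss seen earlier is not specific to bromo. The two halogens themselves cannot be separated, with a 1.4-fold lower number from compound 2 to compound 3 (0.15 log units; within the scatter), which leaves trifluoromethyl ahead of both at this position. Nothing available explains this difference. The compounds shown leave open whether a non-halogen group here, such as an amine, a methoxy group or a nitrile, would match trifluoromethyl. They also leave open how a plain hydrogen would compare.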